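The source may report more compounds than this note shows. Statements on the series, on what has been measured and on what is new or still open speak of the compounds shown alone.

Working notes on the series.

Compound 1 `CC(C)C1(C)CCOC1=O` is measured in a functional assay on the whole organism with Mus musculus as the target, in the maximal electroshock model; a higher number here means that more compound is needed for the effect, a lower number that less compound is needed. In this assay compound 1 gives only a limit, > 500 mg/kg. Compound 2 `CC(C)C1(C(C)C)CCOC1=O` carries the change isopropyl in place of methyl on a saturated ring carbon on the same core, and in this assay compound 2 gives 137 mg/kg. The step of an at least 3.6-fold lower number from compound 1 to compound 2 (0.56 log units; beyond the scatter) is beyond the scatter, and it starts from the limit of > 500 mg/kg in this assay, at which 2 of the 3 values shown sit.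

Compound 3 `CC(C)C1(C)CCSC1=O` has a different core; the difference between the core of compound 3 and the core of compound 1 is not broken down here. In this assay compound 3 gives only a limit, > 500 mg/kg.

Compound 4 `CC(C)C1(C(C)C)CCSC1=O` is not yet measured. It differs from compound 3 by isopropyl in place of methyl on a saturated ring carbon. For the measured compounds named here, this is the same kind of change as the one from compound 1 to compound 2, though not the same: around the place, the ring of compound 4 holds a sulfur where the ring of compound 2 holds an oxygen, and the carbon sits two ring bonds from the ring sulfur rather than from the ring oxygen.

For compound 4 the step of an at least 2.7-fold lower number from compound 3 to compound 4 (0.44 log units; beyond the scatter) is expected, set beside an at least 3.6-fold lower number from compound 1 to compound 2 (0.56 log units; beyond the scatter), because the measured value of compound 3 is a limit > 500 mg/kg and the measured change in the other core is an at least 3.6-fold lower number from compound 1 to compound 2 (0.56 log units; beyond the scatter). Compound 4 is estimated at 180 mg/kg, within 80 mg/kg to 500 mg/kg, with a fair chance that only a limit is reported again.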

Compound 4, dose for half-maximal effect: > 500 mg/kg
Compound 4 gave a limit, no number; the forecaster's own chance of this, stated with the estimate: 30%; middle value at least 2.7-fold (0.44 log units) away from the limit.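

In this assay compound 3 and compound 4 both give only a limit, so no step can be read between them: the limit of > 500 mg/kg in this assay, at which 3 of the 4 values shown sit.

The compounds shown leave open whether isopropyl in place of methyl on a saturated ring carbon changes the number at all on the core of compound 3, as neither compound 3 nor compound 4 has a measured number.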